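Swapping a Hydroxy for a Chloro: What to Expect

The source may report more compounds than this note shows. Statements on the series, on what has been measured and on what is new or still open speak of the compounds shown alone.

Compound 1 `COc1ccc(C(=O)/C=C/c2cc3ccccc3[nH]c2=O)cc1`: 18100 nM
Compound 2 `O=C(/C=C/c1cc2ccccc2[nH]c1=O)c1ccc(O)cc1`: 13300 nM

In a functional assay on SK-MEL-5 cells (Homo sapiens) for cytotoxicity, read by sulforhodamine B assay, with a stated time of 24 h (a lower number here means a stronger inhibitor of growth, a higher number a weaker inhibitor of growth), compound 1 gives 18100 nM and compound 2 gives 13300 nM. Compound 2 holds the lower of the two numbers, but the step of a 1.4-fold lower number from compound 1 to compound 2 (0.13 log units; within the scatter) falls within the scatter, so the pair cannot be told apart. Compound 3 `O=C(/C=C/c1cc2ccccc2[nH]c1=O)c1ccc(Cl)cc1` differs from compound 2 by chloro in place of hydroxy on an aromatic carbon. Going by the values given here, no measured step introduces a chloro; the only step known, a 1.4-fold lower number from compound 1 to compound 2 (0.13 log units; within the scatter), alters this same group and stayed within the scatter, which offers little guidance. Compound 3 is therefore expected to give 10000 nM, with a range of 3500 nM to 30000 nM. The expected step is a 1.3-fold lower number from compound 2 to compound 3 (0.12 log units; within the scatter), not beyond the scatter.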

Compound 3, concentration for total growth inhibition: > 100000 nM
Compound 3 ended at the assay's limit; the forecaster's own chance of this, stated with the estimate: 5%; at least 10-fold (1.00 log units) between middle value and limit.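

In this assay the group on this aromatic carbon turns out to matter. Chloro in place of hydroxy gives an at least 7.5-fold higher number from compound 2 to compound 3 (0.87 log units; beyond the scatter) and chloro in place of methoxy gives an at least 5.5-fold higher number from compound 1 to compound 3 (0.74 log units; beyond the scatter) whereas hydroxy in place of methoxy stayed within the scatter. The result for compound 3 is a limit of the assay, not a number: the limit of > 100000 nM in this assay, at which 1 of the 3 values shown sits.

On these data alone, how far compound 3 truly lies past that limit remains open. Also open, as far as these compounds go, is whether an amine or a carboxylic acid on this same carbon would stay close to compound 1 and compound 2 or fall away like chloro.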